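The compounds below may be only part of what the source reports. "The series", "measured", "known", "first", "only" and "open" are said of these compounds alone.

Compound 1 `Cc1cn(COC(CO)CO)c2ncnc(N)c12` gives > 100000 nM in a functional assay on L1210 cells (Mus musculus) for inhibition; a higher number here means a weaker inhibitor, a lower number a stronger inhibitor; that is a limit of the assay, not a number.
Compound 2 `OCC(CO)OCn1cc(I)c2c(NO)ncnc21` gives 39000 nM in this assay.
Compound 3 `OC[C@H]1O[C@@H](n2cc(Br)c3c(NO)ncnc32)[C@H](O)[C@@H]1O` gives 25000 nM in this assay.

Compound 1 therefore stands at the edge of what can be seen: it sits at the limit of > 100000 nM in this assay, at which 1 of the 3 values shown sits, with no number to place it among the other two. Compound 4 `Nc1ncnc2c1c(Cl)cn2COC(CO)CO` differs from compound 1 by chloro in place of methyl on an aromatic carbon. For the measured compounds named here, no pair of measured compounds isolates this change, so its size must be guessed. The account expects a modest gain for compound 4, placing an at least 1.6-fold lower number from compound 1 to compound 4 (0.22 log units; that floor lies within the scatter), since weak inhibition is all the measured set shows. Compound 4 is estimated at 60000 nM, in the range 20000 nM to 200000 nM.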

Compound 4, half-maximal inhibitory concentration: 2300 nM
Estimate against measurement, compound 4: 26-fold (1.42 log units) above, outside the stated range (below it).
By their numbers in this assay, from the lowest: compound 4; then compounds 3 and 2 (each within the scatter of the next). At a limit, above all of these: compound 1.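

Putting chloro in place of methyl on an aromatic carbon brings an at least 43-fold lower number from compound 1 to compound 4 (1.63 log units; beyond the scatter), so a change of one heavy atom at this position is enough to lift the shared core out of the weak inhibition seen so far in this assay. The step is only a floor because compound 1 carries a limit, not a number: the limit of > 100000 nM in this assay, at which 1 of the 4 values shown sits.

The compounds shown leave open how a nitrile or an ethyl group would read at this position. They also leave open whether chloro gives a similar step on other side chains.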